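A few compounds are considered here, and "the series" means these few. Any claim that something is new, unique, unknown or untested is made for them only; others in the source may bear on it.

Of the compounds shown here, three sharing one core have been tested in an ADME assay on Akata cells (Homo sapiens) for cytotoxicity, with a stated time of 7 days; on this read-out higher numbers stand for lower toxicity in this test and lower numbers for higher toxicity in this test. Compound 1 `Nc1nc(NC2CC2)c2ncn(/C=C3/CC3(CO)CO)c2n1` carries a cyclopropylamino group on an aromatic carbon. In this assay compound 1 gives > 20000 nM, which is a limit of the test rather than a number. Compound 2 `COCCOc1nc(N)nc2c1ncn2/C=C1/CC1(CO)CO` carries 2-methoxyethoxy in place of cyclopropylamino on an aromatic carbon. In this assay compound 2 gives > 20000 nM, again a limit. Compound 3 `Nc1nc(SC2CCCC2)c2ncn(/C=C3/CC3(CO)CO)c2n1` carries cyclopentylsulfanyl in place of cyclopropylamino on an aromatic carbon. In this assay compound 3 gives > 20000 nM, also a limit. Compound 3 thus stands where the other two stand, and none of the three can be ranked. Between them, a step that the two limits leave unreadable from compound 1 to compound 2, a step that the two limits leave unreadable from compound 1 to compound 3 and a step that the two limits leave unreadable from compound 2 to compound 3 all remain unreadable because of the limit of > 20000 nM in this assay, at which 3 of the 3 values shown sit.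

Compound 4 `Nc1nc(SCc2ccccc2)c2ncn(/C=C3/CC3(CO)CO)c2n1` has not yet been measured. It differs from compound 3 by benzyl in place of cyclopentyl on a sulfur. Among the compounds with values here, no measured step bears on this change in a readable way, since every step among the three known compounds is unsized. With all known values sitting at the limit, the step that the limit leaves unreadable from compound 3 to compound 4 is expected to be none beyond the scatter. Compound 4 is expected to give 25000 nM in this assay, within a range from 10000 nM to 60000 nM, and most likely to be reported only as a limit.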

Compound 4, half-maximal cytotoxic concentration: > 20000 nM
Compound 4: no number, only a limit (the forecaster's own chance of this, stated with the estimate: 80%); the middle value is on the limit's open side.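

Compound 4 sits at the same limit of the test as compound 1, compound 2 and compound 3, so none of its steps to those three can be read: the limit of > 20000 nM in this assay, at which 4 of the 4 values shown sit.

In this assay the compounds shown leave open whether any of the four groups on the shared core sets one compound apart from another.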